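A few compounds are considered here, and "the series" means these few. Any claim that something is new, unique, unknown or untested is made for them only; others in the source may bear on it.

Measured so far in a functional assay on HL-60 cells (Homo sapiens) for antiproliferative activity, read by MTT assay, with a stated time of 72 h; a lower number here means a stronger inhibitor, a higher number a weaker inhibitor:

compound 1, `CN(C(=O)C(C)(C)C)c1ccc2[nH]c(-c3n[nH]c4ccccc34)cc2n1`: 4990 nM
compound 2, `CN(C(=O)c1ccc(Br)cc1)c1ccc2[nH]c(-c3n[nH]c4ccccc34)cc2n1`: 1080 nM

Compound 2 holds the lowest number of the two; its nearest neighbour is compound 1, and the step from compound 1 to compound 2 is a 4.6-fold lower number from compound 1 to compound 2 (0.66 log units; beyond the scatter), a modest gain on exchanging tert-butyl for 4-bromophenyl on a carbonyl carbon.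

Compound 3, `CN(c1ccc2[nH]c(-c3n[nH]c4ccccc34)cc2n1)S(=O)(=O)c1ccccc1`, is not yet measured. Relative to compound 2 the change is phenylsulfonyl in place of (4-bromophenyl)carbonyl on a nitrogen on an aromatic ring. Within the data shown here, the only step known bears on it indirectly: it shows the aryl group on the carbonyl is worth something over a saturated group, but it says nothing about exchanging the carbonyl for a sulfonyl, nor about losing the bromine. The shared core and the methyl on the ring nitrogen are unchanged. With one step only, no firm direction can be drawn; the loss of the bromine and the new sulfonyl are both untested, so a wide range is needed.

The expectation for compound 3 in this assay is a somewhat higher number than for compound 2, estimated at 2500 nM, with a range of 600 nM to 10000 nM. That estimate corresponds to a step of a 2.3-fold higher number from compound 2 to compound 3 (0.36 log units; beyond the scatter), expected to fall near the edge of the scatter.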

Compound 3, half-maximal inhibitory concentration: 3700 nM
The estimate for compound 3 lay 1.5-fold (0.17 log units) below the measured number; measured number inside the range.
By their numbers in this assay, from the lowest: compound 2; then compounds 3 and 1 (each within the scatter of the next).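

In this assay, among these compounds, compound 3 is the first member of the series without a carbonyl on this nitrogen, and phenylsulfonyl in place of (4-bromophenyl)carbonyl gives a 3.4-fold higher number from compound 2 to compound 3 (0.53 log units; beyond the scatter) in a modest loss. Against the saturated group, the exchange gives a 1.3-fold lower number from compound 1 to compound 3 (0.13 log units; within the scatter) and leaves compound 3 level with compound 1, so an aromatic ring on this position does not by itself match compound 2: compound 3 carries such a ring, while compound 1 has none. No measurement available here explains either step.

The step to compound 3 removes the bromine and replaces the carbonyl with a sulfonyl at once, so the share of each remains unresolved, and a 4-bromophenylsulfonyl group or an unsubstituted benzoyl group on the same nitrogen would separate the two changes. Also open, as far as these compounds go, is how a methylsulfonyl group, or a carbonyl bearing a chain that ends in an amine, would read at this position, and whether the methyl on the nitrogen matters to any of these steps.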